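The compounds below may be only part of what the source reports. "The series", "measured", "known", "first", "only" and "open" are said of these compounds alone.

Compound 1 `C=CCOc1nc(N)nc2c1ncn2/C=C1/CC1(CO)CO`: > 20000 nM
Compound 2 `CCCNc1nc(N)nc2c1ncn2/C=C1/CC1(CO)CO`: "not determined" (no result reported)

In an ADME assay on MOLT-3 cells (Homo sapiens) for cytotoxicity, with a stated time of 7 days (a higher number here means that more compound is tolerated, a lower number that less compound is tolerated), compound 1 gives > 20000 nM, which is a limit of the assay and not a number. For the measured compounds named here, the only reading so far is the limit of > 20000 nM in this assay, at which 1 of the 2 values shown sits. Compound 2 stands at "not determined" (no result reported) in this assay, so it has no place of its own on the scale.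

Compound 3 `Nc1nc(NC2CCCC2)c2ncn(/C=C3/CC3(CO)CO)c2n1` is still unmeasured. The structural change is cyclopentyl in place of propyl on a nitrogen on an aromatic ring. Going by the values given here, the series offers no measured step to size this change. In this assay no step beyond the usual scatter is expected, and no direction is favoured. A reading at the assay limit remains likely. For compound 3 the expected value is 20000 nM, with an estimated range of 8000 nM to 50000 nM.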

Compound 3, half-maximal cytotoxic concentration: > 20000 nM
Compound 3 was reported as a limit; the forecaster's own chance of this, stated with the estimate: 65%; the middle value lies on the limit itself.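

Compound 1 and compound 3 both stand at a limit of this assay, so no step can be read between them: the limit of > 20000 nM in this assay, at which 2 of the 3 values shown sit.

The compounds shown leave open whether any group at this place brings a numerical reading in this assay, and where compound 2 falls on that scale.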